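From cyclohexyl to 4-chlorophenyl at the assay limit

The compounds below may be only part of what the source reports. "The series", "measured", "known", "first", "only" and "open" are said of these compounds alone.

Compound 1 (`O=C1COc2ccc(-c3cnc(Cl)c(NS(=O)(=O)c4ccc(F)cc4)c3)cc2N1C1CCCCC1`): > 40000 nM
Compound 2 (`COc1cccc(N2C(=O)COc3ccc(-c4cnc5ccccc5c4)cc32)c1`): > 40000 nM
Compound 3 (`COc1cccc(N2C(=O)COc3ccc(-c4cccc(NS(=O)(=O)c5ccc(F)cc5)c4)cc32)c1`): > 40000 nM

All three compounds were tested in a functional assay on MCF7 cells (Homo sapiens) for antiproliferative activity, read by MTT assay, with a stated time of 72 h (a higher number here means a weaker inhibitor, a lower number a stronger inhibitor), and none gave a measured potency. Compound 1 stands at > 40000 nM in this test, which is a limit of the assay and not a number. Its neighbours offer no ranking, as the shared reading is the limit of > 40000 nM in this assay, at which 3 of the 3 values shown sit, for the whole set.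

The next compound to be tested, compound 4 (`O=C1COc2ccc(-c3cnc(Cl)c(NS(=O)(=O)c4ccc(F)cc4)c3)cc2N1c1ccc(Cl)cc1`), keeps the core of compound 1 and changes one group, with 4-chlorophenyl in place of cyclohexyl on an amide-type nitrogen in a ring. Compound 3 also has a six-membered aromatic ring of carbon only on that nitrogen, and compound 3 reads > 40000 nM as a limit too. On that evidence, no step beyond the scatter is expected in this assay for this change, and a further limit reading is the likeliest result. The estimated change is (an at least 1.3-fold lower number from compound 1 to compound 4 (0.12 log units; that floor lies within the scatter)) for this swap. For compound 4 the estimated value is 30000 nM with an expected range of 10000 nM to 40000 nM in this test.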

Compound 4, half-maximal inhibitory concentration: 32800 nM
Compound 4: middle estimate off by 1.1-fold (0.04 log units), on the low side, and the stated range covers the measured number.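

In this assay compound 4 gives 32800 nM, the only value among the compounds shown that is a number and not a limit of the assay. The step is an at least 1.2-fold lower number from compound 1 to compound 4 (0.08 log units; that floor lies within the scatter), so on this nitrogen the swap from cyclohexyl to 4-chlorophenyl cannot be told apart from no change, and a six-membered aromatic ring of carbon only shows no gain beyond the scatter over the non-aromatic ring it replaces. The pair therefore adds only a single reading at the weak end of this test, and the set as a whole stays at its edge: the limit of > 40000 nM in this assay, at which 3 of the 4 values shown sit.

The compounds shown leave open whether a group of another kind on the amide-type nitrogen, such as a short chain ending in an amine or a carboxylic acid, would give a reading clearly apart from that of compound 4. They also leave open whether a smaller substituent there, such as methyl, or a hydrogen in its place, would read any differently in this assay.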